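The source may hold more compounds than are shown below. What is called first, only, known or untested is meant among the compounds shown, and "the series" means these compounds.

Working notes on the series. In an ADME assay on microsomes from liver (Rattus norvegicus) for metabolic stability, read by LC-MS, using NADPH, at 37 degrees C (a lower number here means that the compound disappears faster, a higher number that the compound lasts longer), compound 1 `Cc1cc(C)c(-c2nc(CN3CCC(C(=O)NCCCN4C[C@H](C)C[C@H](C)C4)CC3)c(C)o2)c(C)c1` gives > 0.5 h, which is a limit of the assay and not a number. Going by the values given here, compound 2 `COc1cccc(F)c1-c1nc(CN2CCC(C(=O)NCCCN3C[C@H](C)C[C@H](C)C3)CC2)c(C)o1` gives 0.143 h, the only actual number so far, and it stands clearly under the other entry. Compound 3 `COc1cccc(OC)c1-c1nc(CN2CCC(C(=O)NCCCN3C[C@H](C)C[C@H](C)C3)CC2)c(C)o1` follows from compound 2 with methoxy in place of fluoro on an aromatic carbon, ortho to a large group (methoxy in place of fluoro on an aromatic carbon), which turns 2-fluoro-6-methoxyphenyl into 2,6-dimethoxyphenyl.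

Among the compounds with values here, one measured step bears on this change: an at least 3.4-fold lower number from compound 1 to compound 2 (0.54 log units; beyond the scatter), seen when 2-fluoro-6-methoxyphenyl replaced 2,4,6-trimethylphenyl. Its size is only a lower bound, given (the limit of > 0.5 h in this assay, at which 1 of the 2 values shown sits). That step changed the whole substituted ring at once, so it does not separate the share of fluoro from that of methoxy, and it offers only a weak guide for swapping one of them. A small shift in this assay is therefore expected, with a slight lean towards a lower number. The expected step is a 1.2-fold lower number from compound 2 to compound 3 (0.08 log units; within the scatter), an estimate that stays within the scatter. For compound 3 the estimated half-life is 0.12 h, with an expected range from 0.06 h to 0.25 h.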

Compound 3, half-life: 0.2 h
Compound 3: middle estimate off by 1.7-fold (0.22 log units), on the low side; measured number inside the range.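

In this assay, methoxy in place of fluoro on this aromatic carbon, ortho to a large group, gives a 1.4-fold higher number from compound 2 to compound 3 (0.15 log units; within the scatter), so the two groups cannot be told apart here in this read-out, and the series tolerates this change without a clear shift. The comparison with the 2,4,6-trimethylphenyl compound holds for the second ring as well, with an at least 2.5-fold lower number from compound 1 to compound 3 (0.39 log units; beyond the scatter), so the gap seen earlier with 2-fluoro-6-methoxyphenyl is not confined to that one ring and also appears with 2,6-dimethoxyphenyl. The value of compound 1 is a limit of the assay, so the size of this step is only a lower bound: the limit of > 0.5 h in this assay, at which 1 of the 3 values shown sits.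

The compounds shown leave open how a chloro, a methyl or a trifluoromethyl group on this aromatic carbon would read against fluoro and methoxy. They also leave open which of the three methyl groups of 2,4,6-trimethylphenyl accounts for the gap to compound 3, and a ring carrying one methyl together with one methoxy would begin to separate these shares.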